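The source may report more compounds than this note shows. Statements on the series, on what has been measured and on what is new or still open speak of the compounds shown alone.

- compound 1 `Cc1c(Cc2ccccc2)c(=O)oc2cc(OCCOc3no[n+]([O-])c3S(=O)(=O)c3ccccc3)ccc12` 2 nM
- compound 2 `COc1cc(OCCOc2no[n+]([O-])c2S(=O)(=O)c2ccccc2)ccc1C(=O)/C=C/c1ccc(F)cc1` 3.5 nM

In a functional assay on A549 cells (Homo sapiens) for antiproliferative activity, read by MTT assay, with a stated time of 48 h (on this read-out higher numbers stand for weaker inhibition and lower numbers for stronger inhibition), compound 2 gives 3.5 nM and lies within the scatter of compound 1 with 2 nM on the same read-out. Compound 3 `COc1cc(OCCOc2no[n+]([O-])c2S(=O)(=O)c2ccccc2)ccc1C(=O)/C=C/c1ccccc1` carries hydrogen in place of fluoro on an aromatic carbon, para to a large group, so that 4-fluorophenyl becomes phenyl (hydrogen in place of fluoro on an aromatic carbon). Within the data shown here, no measured pair shows this change, and no step beyond the scatter is expected in this assay in either direction. The expected change is a 1.4-fold higher number from compound 2 to compound 3 (0.15 log units; within the scatter) and stays small. Compound 3 is estimated at 5 nM with an expected range from 1.5 nM to 18 nM for repeated measurements.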

Compound 3, half-maximal inhibitory concentration: 3.3 nM
Beside the measured number, compound 3's estimate is 1.5-fold (0.18 log units) above it; measured number inside the range.
By their numbers in this assay, from the lowest: compounds 1, 3 and 2 (each within the scatter of the next).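

In this assay, among these compounds, replacing fluoro with hydrogen on the aromatic carbon para to a large group, so that 4-fluorophenyl becomes phenyl, gives a 1.1-fold lower number from compound 2 to compound 3 (0.03 log units; within the scatter) and provides the first direct reading at this position. On this read-out, fluoro and hydrogen cannot be told apart there, so nanomolar activity does not depend on the fluoro. No measurement shown offers an explanation for this result. From the compounds shown here alone, it remains open whether a larger or charged group at this position, such as an amine or a carboxylic acid, would keep activity in this range.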